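This account rests on a few compounds, and the source may have more. Where it says the series, first, only, none or still open, it means among the compounds named here.

Measured so far in a functional assay on T47D cells (Homo sapiens) for cytotoxicity, read by MTT assay, with a stated time of 2 days; on this read-out higher numbers stand for weaker inhibition and lower numbers for stronger inhibition:
- Compound 1 `Cc1ccc2c(=O)[nH]c(-c3ccccc3C)nc2c1`: > 50000 nM
- Compound 2 `Cc1ccc2c(=O)[nH]c(-c3ccccc3OC(F)(F)F)nc2c1`: > 50000 nM
- Compound 3 `Cc1ccc2c(=O)[nH]c(-c3ccccc3F)nc2c1`: > 50000 nM

Compound 3 stands at > 50000 nM, which is a limit and not a number. The same holds for compound 1 and compound 2, so the whole set sits at the limit of > 50000 nM in this assay, at which 3 of the 3 values shown sit.

Compound 4 `Cc1ccc2c(=O)[nH]c(-c3ccccc3N(C)C)nc2c1` keeps the shared core and changes one group: dimethylamino in place of fluoro on an aromatic carbon. Dimethylamino takes the place of fluoro on an aromatic carbon of a six-membered aromatic ring of carbon only, ortho to a large group.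

The closest guides are the other single-group swaps on an aromatic carbon: a step that the two limits leave unreadable from compound 1 to compound 2, a step that the two limits leave unreadable from compound 1 to compound 3 and a step that the two limits leave unreadable from compound 2 to compound 3. None of them has a readable size, as both ends of each are limits. Methyl, trifluoromethoxy and fluoro thus give no measured trend to carry forward, and none of them brought a number into view. No clear step is therefore expected in this assay, and another limit is the likeliest result. The expected outcome is a number no higher from compound 3 to compound 4 (the limit leaves the size open). For compound 4 the estimated value is 50000 nM, with an expected range of 20000 nM to 100000 nM.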

Compound 4, half-maximal inhibitory concentration: 4430 nM
Beside the measured number, compound 4's estimate is 11-fold (1.05 log units) above it; the whole stated range lies above it.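

In this assay, within the data shown here, dimethylamino on this aromatic carbon, ortho to a large group, gives the first readable number in the set, with an at least 11-fold lower number from compound 3 to compound 4 (1.05 log units; beyond the scatter), an at least 11-fold lower number from compound 2 to compound 4 (1.05 log units; beyond the scatter) and an at least 11-fold lower number from compound 1 to compound 4 (1.05 log units; beyond the scatter). So this position does not shut out activity on the shared core, and the choice of group here can decide whether a number appears at all, something that methyl, trifluoromethoxy and fluoro could not show. The steps among compounds 1, 2 and 3 cannot be read, and each new step gives only a minimum size, because all three partners of compound 4 stop at the same ceiling: the limit of > 50000 nM in this assay, at which 3 of the 4 values shown sit.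

With a single compound carrying a number, nothing shows which feature of dimethylamino matters, and the hydrogen-bond acceptor it brings in, where fluoro brings none, is so far only a count and not an explanation. Close relatives at the same place, such as a plain amine, methylamino, diethylamino or a morpholine ring, would show whether the effect belongs to amines in general or to this one group.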